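This account rests on a few compounds, and the source may have more. Where it says the series, first, only, none or still open, it means among the compounds named here.

Measured in a functional assay on HeLa cells (Homo sapiens) for cytotoxicity, read by MTT assay, with a stated time of 72 h; on this read-out lower numbers stand for stronger inhibition and higher numbers for weaker inhibition:
- compound 1 `COc1ccc(-n2c(=O)c(C(=O)Nc3ccc(Oc4ncnc5c4ccn5C)cc3)cc3cccnc32)cc1`: 65800 nM
- compound 2 `Cn1ccc2c(Oc3ccc(NC(=O)c4cc5cccnc5n(-c5ccccc5)c4=O)cc3F)ncnc21`: 51800 nM
- compound 3 `O=C(Nc1ccc(Oc2ncnc3[nH]ccc23)c(F)c1)c1cc2cccnc2n(-c2ccccc2)c1=O`: 36900 nM

All three values lie within the usual scatter of one another, so compound 3, at 36900 nM, stands level with the other two in this assay.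

Compound 4 `O=C(Nc1ccc(Oc2ncnc3[nH]ccc23)c(F)c1)c1cc2cccnc2n(-c2ccc(Br)cc2F)c1=O` differs from compound 3 by 4-bromo-2-fluorophenyl in place of phenyl on an aromatic nitrogen. Going by the values given here, the only measured single change, a 1.4-fold lower number from compound 2 to compound 3 (0.15 log units; within the scatter), is a swap of hydrogen for methyl elsewhere in the molecule, so it says little about this one. With no direct evidence, no shift beyond the scatter is expected in this assay, and the expected change is a 1.2-fold lower number from compound 3 to compound 4 (0.09 log units; within the scatter). For compound 4 the estimated value is 30000 nM, with an expected range from 10000 nM to 70000 nM.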

Compound 4, half-maximal inhibitory concentration: 87800 nM
Compound 4: the middle estimate sits 2.9-fold (0.47 log units) below what was measured; measured number above the stated range.
By their numbers in this assay, from the lowest: compounds 3, 2, 1 and 4 (each within the scatter of the next, the first and the last beyond it).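

In this assay putting 4-bromo-2-fluorophenyl in place of phenyl on the aromatic nitrogen gives a 2.4-fold higher number from compound 3 to compound 4 (0.38 log units; beyond the scatter) and so moves towards weaker inhibition. Going by these compounds alone, this is the first step here that goes beyond the scatter, which shows that this position responds to a change in its group, if only modestly. No measurement here explains the shift.

Fluorine and bromine enter together, so their separate shares of the step stay open. Also open, going by these compounds, is how a phenyl carrying an amine or a carboxylic acid would read at this position.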